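A few compounds are considered here, and "the series" means these few. Any claim that something is new, unique, unknown or untested is made for them only; others in the source may bear on it.

Measured so far in an ADME assay on MT4 cells (Homo sapiens) for cytotoxicity; on this read-out higher numbers stand for lower toxicity in this test and lower numbers for higher toxicity in this test:
compound 1, `O=c1[nH]c2ccc(Cl)cc2n1Cc1c(F)cccc1F`: > 424000 nM.
compound 2, `O=c1[nH]c2ccc(Cl)cc2n1S(=O)(=O)c1c(F)cccc1F`: 194000 nM.
compound 3, `Cc1ccc2[nH]c(=O)n(Cc3c(F)cccc3F)c2c1`: 236000 nM.

For compound 1 the figure is only a limit of the assay, (the limit of > 424000 nM in this assay, at which 1 of the 3 values shown sits). Compound 2 and compound 3 lie within the usual scatter of each other. The change methyl in place of chloro on an aromatic carbon gives an at least 1.7-fold lower number from compound 1 to compound 3 (0.25 log units; that floor lies within the scatter). How the core of compound 2 differs from the core of compound 1 is not broken down here.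

Compound 4, `Cc1ccc2[nH]c(=O)n(S(=O)(=O)c3c(F)cccc3F)c2c1`, is not yet measured; it carries the same change relative to compound 2, (methyl in place of chloro on an aromatic carbon), at a place described in identical words. For compound 4 the expected step is a 1.3-fold lower number from compound 2 to compound 4 (0.11 log units; within the scatter); this rests on an at least 1.7-fold lower number from compound 1 to compound 3 (0.25 log units; that floor lies within the scatter), whose floor lies within the scatter, so little movement is expected. Compound 4 is estimated at 150000 nM in this assay, between 70000 nM and 320000 nM.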

Compound 4, half-maximal cytotoxic concentration: 2220 nM
Beside the measured number, compound 4's estimate is 68-fold (1.83 log units) above it, outside the stated range (below it).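

In this assay, methyl in place of chloro on an aromatic carbon gives an 87-fold lower number from compound 2 to compound 4 (1.94 log units; beyond the scatter), a large step on the core of compound 2. Set beside the earlier case, the comparison remains incomplete: the same change on two cores in this assay, an at least 1.7-fold lower number (0.25 log units; that floor lies within the scatter) from compound 1 to compound 3 and an 87-fold lower number (1.94 log units; beyond the scatter) from compound 2 to compound 4; the limit leaves it open whether they differ. Compound 1 gives > 424000 nM, which is a limit of the assay and not a number; whether the change acts differently on the two cores or carries over unchanged is therefore not shown.

The compounds shown leave open whether the large step is tied to methyl in particular or would also appear with another group at this place on the core of compound 2, such as a methoxy group or a nitrile. A firm comparison between the cores also still needs a number in place of the limit for compound 1.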